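Removing the remaining methoxy group from compound 1

The source may report more compounds than this note shows. Statements on the series, on what has been measured and on what is new or still open speak of the compounds shown alone.

Measured compounds:
compound 1, `COc1cc(/C=C/C(=O)O)ccc1OC(=O)c1nc(C)c(C)nc1C`, 55.4%
compound 2, `COc1cc(/C=C/C(=O)O)cc(OC)c1OC(=O)c1nc(C)c(C)nc1C`, 163%
compound 3, `CCOC(=O)/C=C/c1cc(OC)c(O)c(OC)c1`, 69.1%

In a functional assay on EA.hy 926 cells (Homo sapiens) for cytotoxicity, read by MTT assay, with stated times of 24 h and 12 h, tested at 100 uM (a higher number here means a stronger effect of the compound at the concentration tested, a lower number a weaker effect), compound 1 gives 55.4%, the lowest of the three numbers. Its nearest neighbour is compound 3 with 69.1%, a gap beyond the scatter; furthest away is compound 2 with 163%. Within the data shown here, the one step between measured compounds that differ in a single place is a number 107.6 percentage points higher from compound 1 to compound 2 (beyond the scatter), which adds a methoxy group on an aromatic carbon of the shared core.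

Compound 4, `Cc1nc(C)c(C(=O)Oc2ccc(/C=C/C(=O)O)cc2)nc1C`, has not yet been measured in this assay. It differs from compound 1 as follows:
hydrogen in place of methoxy on an aromatic carbon

Among the measured compounds shown here, this is the reverse kind of change to the one seen going from compound 1 to compound 2, where a methoxy group entering raised the number by a large amount. For the measured compounds named here, only that step bears on the present question, and it points one way: fewer methoxy groups went with a lower number. Whether the removal of the last methoxy group lowers the number as strongly as the addition raised it cannot be told from three compounds, so the expectation is a moderate fall.

Compound 4 is therefore estimated at 38% in this assay, within 8% to 72%. This expectation corresponds to a step of a number 17.4 percentage points lower from compound 1 to compound 4 (beyond the scatter).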

Compound 4, a percentage reported as activity, at one concentration (the size of the read-out at that concentration, not a potency): 93.2%
Compound 4: middle estimate off by 55.2 percentage points, on the low side; the whole stated range lies below it.
By their numbers in this assay, from the lowest: compound 1; then compound 3; then compound 4; then compound 2.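

In this assay hydrogen in place of methoxy on this aromatic carbon, ortho to a large group and meta to a 2-carboxyethenyl group, gives a number 37.8 percentage points higher from compound 1 to compound 4 (beyond the scatter) and so raises the number. Among these compounds, the earlier change, methoxy in place of hydrogen on an aromatic carbon, gives a number 107.6 percentage points higher from compound 1 to compound 2 (beyond the scatter) and runs in the same direction, so losing the one methoxy group and gaining another both lead upward from compound 1. The number therefore does not follow the count of methoxy groups in one direction across compound 4, compound 1 and compound 2, and compound 1 lies below both of its neighbours that differ from it in one place. Nothing given here accounts for either step.

The compounds shown leave open whether another group on this carbon, such as ethoxy or a chlorine atom, would give a number nearer that of compound 1 or that of compound 4. They also leave open whether the rise on removing the methoxy group would persist if an amide took the place of the carboxylic acid.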